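The source may report more compounds than this note shows. Statements on the series, on what has been measured and on what is new or still open speak of the compounds shown alone.

Compounds measured so far:
compound 1, `COc1cc(OCC(=O)Nc2cccc(NC(=O)c3ccc(N(C)C)cc3)c2)ccc1C=O` — 306 nM
compound 2, `CN(C)c1ccc(C(=O)Nc2cccc(NC(=O)COc3ccc4occc(=O)c4c3)c2)cc1` — > 10000 nM
compound 3, `O=C(COc1ccc2c(=O)ccoc2c1)Nc1cccc(NC(=O)c2ccc(F)cc2)c1` — 54 nM

The three compounds were tested in an assay on isolated protein for inhibition of Rho-associated protein kinase 2 (Homo sapiens), read by scintillation counting, radiometric assay and 33P incorporation, with a stated time of 40 min, in the presence of a further agent that is not named here; a lower number here means a stronger inhibitor, a higher number a weaker inhibitor. Among the two compounds with a number, compound 3 stands lowest, with compound 1 as its nearest neighbour at a higher number that lies beyond the scatter. For compound 2 the result is a limit of the assay rather than a number, (the limit of > 10000 nM in this assay, at which 1 of the 3 values shown sits). Among the compounds with values here, the one measured step, an at least 32-fold higher number from compound 1 to compound 2 (1.51 log units; beyond the scatter), concerns the group on the oxygen on the saturated carbon and leaves the amide side of the shared core untouched.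

Compound 4, `O=C(COc1ccc2c(=O)ccoc2c1)Nc1cccc(NC(=O)c2cnc(C(F)(F)F)s2)c1`, has not yet been measured. It differs from compound 3 only at the other end: 2-(trifluoromethyl)-1,3-thiazol-5-yl in place of 4-fluorophenyl on a carbonyl carbon. Within the data shown here, no measured step touches this carbonyl carbon, so the step from compound 1 to compound 2 does not bear on it, and the data give no direct guide to its direction. With nothing to point either way, the expected step of a 1.9-fold higher number from compound 3 to compound 4 (0.27 log units; within the scatter) is small, within or near the scatter. Compound 4 is therefore estimated at 100 nM, in a range from 20 nM to 500 nM.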

Compound 4, half-maximal inhibitory concentration: 10 nM
For compound 4 the middle estimate is 10-fold (1.00 log units) above the measured one; the whole stated range lies above it.
By their numbers in this assay, from the lowest: compound 4; then compound 3; then compound 1. At a limit, above all of these: compound 2.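

In this assay, the carbonyl carbon whose other neighbour is the amide-type nitrogen proves to be a place where a change in the group moves the number beyond the scatter: the step is a 5.4-fold lower number from compound 3 to compound 4 (0.73 log units; beyond the scatter) with 2-(trifluoromethyl)-1,3-thiazol-5-yl in place of 4-fluorophenyl. Within the data shown here, the only earlier measured step concerned the group on the oxygen on a saturated carbon, so this is the first sign that the carbonyl side of the shared core also responds, here with a five-membered aromatic ring in place of a six-membered aromatic ring of carbon only. Ring, substituent and acceptor count all change in this one step, and nothing measured here gives a reason for it.

Still open, from the compounds shown here alone, is whether the step belongs to the ring or to the trifluoromethyl group on it; a 1,3-thiazol-5-yl carrying a methyl group or an amine in that place would separate the two. Also open, going by these compounds, is whether the same group has the same effect on the core of compound 1.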